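Carbamate to Sulfonamide on the Piperidine Nitrogen

The compounds below may be only part of what the source reports. "The series", "measured", "known", "first", "only" and "open" are said of these compounds alone.

This account concerns two measured compounds and one that awaits measurement. Compound 1 `CC(C)OC(=O)N1CCC(Oc2ncnc3c2CCN3c2ccc(S(C)(=O)=O)cc2)CC1` gives 126 nM in a functional assay on CHO-K1 cells for agonist activity at Glucose-dependent insulinotropic receptor (Homo sapiens), read by a luciferase reporter, with a stated time of 5 h; a lower number here means that less compound is needed, a higher number that more compound is needed for the effect. Compound 2 `CCOC(=O)N1CCC(Oc2ncnc3c2CCN3c2ccc(S(C)(=O)=O)cc2F)CC1` gives 251 nM in this assay. Compound 2 carries the higher of the two numbers, but its nearest neighbour, compound 1, sits within the usual scatter of it, so the two values cannot be ordered with confidence. The next compound, compound 3 `CC(C)S(=O)(=O)N1CCC(Oc2ncnc3c2CCN3c2ccc(S(C)(=O)=O)cc2F)CC1`, arises from compound 2 by a single change: isopropylsulfonyl in place of ethoxycarbonyl on an amine nitrogen in a ring. Among the measured compounds shown here, the two measured compounds give no step of this kind to lean on, and the change keeps the acceptor count unchanged while adding a sulfur atom in place of one carbon. Compound 3 is therefore expected to land close to compound 2, with a step of a 1.0-fold lower number from compound 2 to compound 3 (0.00 log units; within the scatter) in this assay that is not expected to exceed the scatter. The estimate for compound 3 in this assay is 250 nM, within a range from 80 nM to 800 nM.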

Compound 3, half-maximal effective concentration: 1260 nM
The estimate for compound 3 lay 5.0-fold (0.70 log units) below the measured number, outside the stated range (above it).
By their numbers in this assay, from the lowest: compounds 1 and 2 (each within the scatter of the next); then compound 3.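

In this assay, putting isopropylsulfonyl in place of ethoxycarbonyl on an amine nitrogen in a ring gives a 5.0-fold higher number from compound 2 to compound 3 (0.70 log units; beyond the scatter) and so separates the two groups at this position, although the count of hydrogen-bond acceptors stays the same. The values of compound 1 and compound 2 lie within the scatter of each other and offered no step at this position, so this single change is the first clear difference among the compounds shown. Nothing measured here accounts for the step, which rests on one pair of compounds alone.

As far as these compounds go, compound 3 changes the linking group and the alkyl group at once, so it stays open whether the higher number follows the sulfonyl or the isopropyl part. An ethylsulfonyl group at this nitrogen would help to tell these apart, while an acetyl group or a urea would show how other carbonyl-linked groups compare with ethoxycarbonyl.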